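This account rests on a few compounds, and the source may have more. Where it says the series, first, only, none or still open, it means among the compounds named here.

Compound 1 `C#CCN1CCC(OC(=O)Nc2ccc(C(C)C)cc2)CC1` gives 178 nM in an assay on BTI-TN-5B1-4 cells for inhibition of Amine oxidase [flavin-containing] B (Homo sapiens), read by fluorescence and Amplex Red, using microsomes, with a stated time of 15 min; a higher number here means a weaker inhibitor, a lower number a stronger inhibitor. Compound 2 `CC(C)c1ccc(NC(=O)OC2CCN(Cc3ccccc3)CC2)cc1` returns only a limit in this assay, reported as > 100000 nM. The change phenyl in place of ethynyl on a saturated chain carbon bound to an amine nitrogen in a ring therefore produced an at least 560-fold higher number from compound 1 to compound 2 (2.74 log units; beyond the scatter), a step whose size is bounded by the limit of > 100000 nM in this assay, at which 2 of the 3 values shown sit. Compound 3 `C#CCN1CCCC(COC(=O)N(C)CC)C1` likewise returns only a limit in this assay, namely > 100000 nM. The difference between the core of compound 3 and the core of compound 1 is not broken down here. Compound 4 `CCN(C)C(=O)OCC1CCCN(Cc2ccccc2)C1` carries the same change that separates compound 2 from compound 1, (phenyl in place of ethynyl on a saturated chain carbon bound to an amine nitrogen in a ring), now made on the core of compound 3. That change once gave an at least 560-fold higher number from compound 1 to compound 2 (2.74 log units; beyond the scatter), and compound 3 already sits at a limit. Compound 4 is therefore expected to show the step that the limit leaves unreadable from compound 3 to compound 4, itself most likely only a limit. Compound 4 is estimated at 300000 nM, between 100000 nM and 1000000 nM.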

Compound 4, half-maximal inhibitory concentration: > 100000 nM
Compound 4 gave a limit, no number; the forecaster's own chance of this, stated with the estimate: 90%; the middle value does not contradict the limit.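

For the compounds shown here, compound 3 and compound 4 each return only a limit, so no step between them can be read: the limit of > 100000 nM in this assay, at which 3 of the 4 values shown sit.
Going by these compounds, whether propargyl to benzyl changes inhibition on the core of compound 3 stays open.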